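Swapping the Sulfamoyl Group for a Methoxy Group

The source may hold more compounds than are shown below. What is called first, only, known or untested is meant among the compounds shown, and "the series" means these compounds.

Two measured compounds share one core. Compound 1 `Cc1cc(Nc2cc(N3CCN(C)CC3)nc(Nc3ccc(C#N)cc3)n2)n[nH]1` carries a cyano group on its aromatic ring, and in a functional assay on MDA-MB-231 cells (Homo sapiens) for antiproliferative activity, read by CCK-8 assay, with a stated time of 72 h (on this read-out lower numbers stand for stronger inhibition and higher numbers for weaker inhibition), compound 1 gives 75.7 nM. Among the compounds with values here, compound 2 `Cc1cc(Nc2cc(N3CCN(C)CC3)nc(Nc3ccc(S(N)(=O)=O)cc3)n2)n[nH]1` carries a sulfamoyl group in that position instead; in this assay compound 2 gives 1210 nM, the highest of the two numbers measured so far. Within the data shown here, the single step known between measured compounds is a 16-fold higher number from compound 1 to compound 2 (1.20 log units; beyond the scatter). Compound 3 `COc1cccc(Nc2nc(Nc3cc(C)[nH]n3)cc(N3CCN(C)CC3)n2)c1` has not yet been measured and differs from compound 2 in one place: 3-methoxyphenyl in place of 4-sulfamoylphenyl on a nitrogen on an aromatic ring. Among the measured compounds shown here, no measured step involves a 3-methoxyphenyl group, so the guide is only that the sulfamoyl group sits on the weak side of the one large step known. A lower number is therefore expected, with a step of about a 6.1-fold lower number from compound 2 to compound 3 (0.78 log units; beyond the scatter), though with wide uncertainty. Compound 3 is estimated at 200 nM, within a range from 50 nM to 800 nM.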

Compound 3, half-maximal inhibitory concentration: 240 nM
Compound 3: the middle estimate sits 1.2-fold (0.08 log units) below what was measured, and the stated range covers the measured number.
By their numbers in this assay, from the lowest: compound 1; then compound 3; then compound 2.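

In this assay the change at this position moves the number in both directions: there is a 5.0-fold lower number from compound 2 to compound 3 (0.70 log units; beyond the scatter) and also a 3.2-fold higher number from compound 1 to compound 3 (0.50 log units; beyond the scatter) in the same series. The 3-methoxyphenyl group therefore sits between the other two groups, with both steps beyond the scatter, so this position on the nitrogen separates three groups rather than two. Nothing shown explains this order.

The name 3-methoxyphenyl differs from 4-cyanophenyl and 4-sulfamoylphenyl both in the group carried and in its number on the ring, so these steps cannot show which of the two differences matters. As far as these compounds go, it also remains open whether a 4-methoxyphenyl group, or a ring carrying an amine or a carboxylic acid, would fall within this span or outside it.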